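Removing a Fluorine from an Acid Ceramidase Inhibitor

The source may report more compounds than this note shows. Statements on the series, on what has been measured and on what is new or still open speak of the compounds shown alone.

Of the compounds shown here, three sharing one core have been measured in an assay on HEK293 cells for inhibition of acid ceramidase (Homo sapiens), read by fluorescence, with stated times of 10 min and 3 h; a higher number here means a weaker inhibitor, a lower number a stronger inhibitor. Compound 1 `CC(C)N1CCC(c2ccc3c(c2)oc(=O)n3C(=O)NCCCCc2ccccc2)CC1` gives 94 nM, compound 2 `CC(C)N1CCN(c2ccc3c(c2)oc(=O)n3C(=O)NCCCCc2ccccc2)CC1` gives 211 nM, and compound 3 `CN1CCC(c2cc3oc(=O)n(C(=O)NCCCCc4ccccc4)c3cc2F)CC1` gives 24 nM. Among the measured compounds shown here, the only measured step among them, a 2.2-fold higher number from compound 1 to compound 2 (0.35 log units; beyond the scatter), concerns the ring attached to the core and not the change considered here. Compound 3 stands lowest of the three numbers: compound 1 is its nearest neighbour, and compound 2 its furthest.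

Compound 4 `CN1CCC(c2ccc3c(c2)oc(=O)n3C(=O)NCCCCc2ccccc2)CC1` differs from compound 3 by hydrogen in place of fluoro on an aromatic carbon. For the measured compounds named here, no measured step involves a fluoro group, so nothing directly shows how large this step should be. Compound 1 also carries no fluoro and gives 94 nM, though it differs from compound 4 in a second place as well. On this thin ground, a modest rise in the number in this assay is expected, a 2.1-fold higher number from compound 3 to compound 4 (0.32 log units; beyond the scatter). Compound 4 is therefore estimated at 50 nM, within a range from 20 nM to 150 nM.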

Compound 4, half-maximal inhibitory concentration: 129 nM
Compound 4: the middle estimate sits 2.6-fold (0.41 log units) below what was measured; the range from low to high includes it.
By their numbers in this assay, from the lowest: compound 3; then compounds 1, 4 and 2 (each within the scatter of the next, the first and the last beyond it).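

In this assay, the fluoro group on the aromatic carbon ortho to the 1-methylpiperidin-4-yl group carries real weight: removing it gives a 5.4-fold higher number from compound 3 to compound 4 (0.73 log units; beyond the scatter) and is the largest step among these four compounds. Once the fluoro is gone, changes at the amine ring stay small, with a 1.4-fold higher number from compound 1 to compound 4 (0.14 log units; within the scatter) for methyl in place of isopropyl on the ring nitrogen and a 1.6-fold lower number from compound 2 to compound 4 (0.21 log units; within the scatter) for 1-methylpiperidin-4-yl in place of 4-isopropylpiperazin-1-yl on the aromatic carbon. No measurement at hand accounts for the effect of this single atom.

The compounds shown leave open whether a chlorine, a methyl or a methoxy group on this same carbon would behave like the fluoro or like the hydrogen. On these data alone, it also remains open whether the fluoro step would have the same size with an isopropyl group on the ring nitrogen.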